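The source may report more compounds than this note shows. Statements on the series, on what has been measured and on what is new or still open speak of the compounds shown alone.

Measured compounds:
Compound 1, `CC(C)C[C@@H](N)CN(C(=O)[C@@H]1C[C@H]1c1ccccc1)c1ccc(-c2ccccc2)cc1`, in a functional assay for agonist activity at G protein-coupled receptor 88 (Homo sapiens), read by HTRF and cAMP accumulation (a lower number here means that less compound is needed, a higher number that more compound is needed for the effect), gives 1.8 nM.
Compound 2, `CC[C@H](C)[C@H](N)CN(C(=O)[C@@H]1C[C@H]1c1ccc(Cl)cc1)c1ccc(-c2ccccc2)cc1`, in this assay gives 4300 nM.
Compound 3, `CCc1ccc(-c2ccc(N(C[C@@H](N)[C@@H](C)CC)C(=O)[C@@H]3C[C@H]3c3ccccc3)cc2)cc1`, in this assay gives 44 nM.

Among these three, compound 3 stands second highest in this assay: its number lies well above that of compound 1 and well below that of compound 2, both gaps beyond the scatter of the assay. Compound 4, `CC[C@H](C)[C@H](N)CN(C(=O)[C@@H]1C[C@H]1c1ccccc1)c1ccc(-c2ccc(CN)cc2)cc1`, has not yet been measured. It differs from compound 3 in one place: amino in place of methyl on a saturated chain carbon bound to an aromatic carbon. Going by the values given here, no pair of measured compounds shows this same change, so its effect can only be judged by expectation. The three values show that the shared core tolerates changes at the outer ring and at the amine-bearing chain, but with swings in both directions that exceed the scatter. The amino group introduced in compound 4 brings a hydrogen-bond donor and acceptor where compound 3 carries only a methyl, and a modest rise in the number in this assay is expected rather than a fall. Compound 4 is therefore estimated at 150 nM, within 30 nM to 800 nM, an expected step of a 3.4-fold higher number from compound 3 to compound 4 (0.53 log units; beyond the scatter).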

Compound 4, half-maximal effective concentration: > 30000 nM
Compound 4: a limit, no number; the forecaster's own chance of this, stated with the estimate: 5%; middle value at least 200-fold (2.30 log units) from the limit.
By their numbers in this assay, from the lowest: compound 1; then compound 3; then compound 2. At a limit, above all of these: compound 4.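

Going by these compounds alone, the earlier compounds offered no change in one place, so this is the first direct reading of the substituent on the outer ring. Replacing 4-ethylphenyl with 4-(aminomethyl)phenyl, which exchanges 1 carbon for 1 nitrogen on a saturated chain carbon bound to an aromatic carbon, gives an at least 680-fold higher number from compound 3 to compound 4 (2.83 log units; beyond the scatter). In this assay compound 4 gives > 30000 nM, which is a limit of the assay and not a number. So this position does not accept every group of this size, and a one-atom exchange here is enough to reach that limit: the limit of > 30000 nM in this assay, at which 1 of the 4 values shown sits.

The compounds shown leave open whether the loss belongs to the amine itself, since a hydroxymethyl or methoxymethyl group at this place would separate the nitrogen from the size of the group. They also leave open how a longer chain, such as propyl, or a carboxylic acid would read here.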